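Swapping a nitroimidazole for a pyridine on the amide tail

The compounds below may be only part of what the source reports. "The series", "measured", "known", "first", "only" and "open" are said of these compounds alone.

Compound 3 `Cc1cc(C)cc(S(=O)(=O)c2c(C(=O)NCC(=O)NCCn3c(C)cnc3[N+](=O)[O-])[nH]c3ccc(Cl)cc23)c1` gives 24500 nM in an ADME assay on MT4 cells (Homo sapiens) for cytotoxicity, read by MTT assay (a lower number here means that less compound is tolerated, a higher number that more compound is tolerated), the highest of the two plain numbers shown. Its nearest neighbour is compound 1 `Cc1cc(C)cc(S(=O)(=O)c2c(C(=O)NC(C)C(=O)NC(C)c3ccncc3)[nH]c3ccc(Cl)cc23)c1`, which gives 21900 nM, a gap within the usual scatter. Compound 2 `Cc1cc(C)cc(S(=O)(=O)c2c(C(=O)NCC(=O)NCc3ccco3)[nH]c3ccc(Cl)cc23)c1` gives > 50000 nM, which is a limit of the assay rather than a number. Within the data shown here, the one measured step, an at least 2.0-fold lower number from compound 2 to compound 3 (0.30 log units; that floor lies within the scatter), is only a floor, since compound 2 sits at the limit of > 50000 nM in this assay, at which 1 of the 3 values shown sits.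

Compound 4 `Cc1cc(C)cc(S(=O)(=O)c2c(C(=O)NCC(=O)NC(C)c3ccncc3)[nH]c3ccc(Cl)cc23)c1` differs from compound 3 by a group of 8 heavy atoms (7 carbon, 1 nitrogen; one six-membered aromatic ring with 1 hetero atom) in place of a group of 11 heavy atoms (6 carbon, 3 nitrogen, 2 oxygen; one five-membered aromatic ring with 2 hetero atoms), on an amide-type nitrogen. The tail that enters in compound 4 is the same 1-(pyridin-4-yl)ethyl group found in compound 1, whose value of 21900 nM sits within the scatter of the value of compound 3, so little movement in this assay is expected. The step from compound 3 to compound 4 is therefore estimated at a 1.1-fold lower number from compound 3 to compound 4 (0.05 log units; within the scatter), essentially none beyond the scatter. Compound 4 is expected to give about 22000 nM, with a likely range from 11000 nM to 45000 nM.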

Compound 4, half-maximal cytotoxic concentration: 47000 nM
Estimate against measurement, compound 4: 2.1-fold (0.33 log units) below, and the stated range ends below it.
By their numbers in this assay, from the lowest: compounds 1, 3 and 4 (each within the scatter of the next, the first and the last beyond it). At a limit, above all of these: compound 2.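

Compound 4 shows that the chain carbon matters here. Among these compounds, with the 1-(pyridin-4-yl)ethyl tail kept, hydrogen in place of methyl on that carbon gives a 2.1-fold higher number from compound 1 to compound 4 (0.33 log units; beyond the scatter) in this assay, the only readable step here that lies beyond the scatter. The 1-(pyridin-4-yl)ethyl group in place of the group of 11 heavy atoms with one five-membered aromatic ring with 2 hetero atoms gives a 1.9-fold higher number from compound 3 to compound 4 (0.28 log units; within the scatter), so that exchange on the amide-type nitrogen cannot be told from the scatter. Compound 2 stands at a limit. The exchange of (furan-2-yl)methyl for 1-(pyridin-4-yl)ethyl on the amide-type nitrogen gives an at least 1.0-fold lower number from compound 2 to compound 4 (0.02 log units; that floor lies within the scatter), which is only a floor, so the size of this step cannot be read: the limit of > 50000 nM in this assay, at which 1 of the 4 values shown sits.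

As far as these compounds go, this methyl step rests on a single pair of compounds, so it is open whether it would recur with any other tail. Also open, from the compounds shown here alone, is what a tail ending in a phenyl ring, an amine or a carboxylic acid would give at this amide-type nitrogen.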